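The source may hold more compounds than are shown below. What is called first, only, known or untested is meant among the compounds shown, and "the series" means these compounds.

Measured so far:
compound 1 `O=C(NC1CCCCC1)Oc1cccc(-c2ccccc2)c1` — 0.712 h
compound 2 `O=C(NC1CCCC1)Oc1cccc(-c2ccccc2)c1` — 0.667 h

Both numbers come from an ADME assay on a cell-free system (plasma, Rattus norvegicus, strain Wistar) for metabolic stability, read by HPLC, tested at 1 uM; a higher number here means that the compound lasts longer, a lower number that the compound disappears faster. Compound 2 and compound 1 lie within the scatter of each other: a 1.1-fold lower number from compound 1 to compound 2 (0.03 log units; within the scatter). So compound 2 has no position of its own on these numbers; the two are, for present purposes, the same.

Compound 3 `CCCCNC(=O)Oc1cccc(-c2ccccc2)c1` differs from compound 2 as follows: butyl in place of cyclopentyl on an amide-type nitrogen. The same difference, cut one bond further out, reads cyclopentylamino to butylamino.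

Among the measured compounds shown here, the only measured step, cyclopentyl in place of cyclohexyl on the amide-type nitrogen, bears on this only loosely: it changed the ring size and gave a 1.1-fold lower number from compound 1 to compound 2 (0.03 log units; within the scatter), nothing beyond the scatter. For the measured compounds named here, exchanging a ring for an open chain is a different kind of change, and no measured pair covers it. With one step of that sort showing no movement, the default expectation for compound 3 is again a step of no clear size in this assay: a 1.1-fold lower number from compound 2 to compound 3 (0.05 log units; within the scatter) is what the estimate amounts to.

Compound 3 is therefore estimated at 0.6 h in this assay, with a range from 0.3 h to 1.2 h.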

Compound 3, half-life in the plasma assay: 0.36 h
For compound 3 the middle estimate is 1.7-fold (0.22 log units) above the measured one, within the range that was stated.
By their numbers in the plasma assay, from the lowest: compounds 3, 2 and 1 (each within the scatter of the next).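

In the plasma assay the open chain butyl on the amide-type nitrogen stays within the scatter of both rings, with a 1.9-fold lower number from compound 2 to compound 3 (0.27 log units; within the scatter) and a 2.0-fold lower number from compound 1 to compound 3 (0.30 log units; within the scatter), so a ring at this position is not shown to be needed for the half-life, although the step from the cyclohexyl compound reaches the edge of the scatter. The same change leaves a physicochemical assay for pharmacokinetics, read by HPLC, at pH 9.0 (a lower number here means that the compound disappears faster, a higher number that the compound lasts longer), equally undivided: compound 2 gives 0.752 h and compound 3 gives 0.715 h, with a 1.1-fold lower number from compound 2 to compound 3 (0.02 log units; within the scatter), so neither read-out separates butyl from cyclopentyl. No measurement at hand offers an explanation for these numbers.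

Butyl is the only open chain among the compounds shown, so chain length and the absence of a ring cannot be told apart in these data. Going by these compounds, whether a longer chain such as hexyl, a branched chain, or an amine or carboxylic acid at the end of the butyl chain would carry the half-life in the plasma assay beyond the scatter remains open.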